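Removing the nitrile from a bis-indolyl pyridine

The compounds below may be only part of what the source reports. "The series", "measured", "known", "first", "only" and "open" are said of these compounds alone.

Compound 2 `COc1ccc2c(c1)c(-c1cc(C(F)(F)F)c(C#N)c(-c3cn(S(=O)(=O)c4ccc(C)cc4)c4ccc(OC)cc34)n1)cn2S(=O)(=O)c1ccc(C)cc1` was tested in a functional assay on A549 cells (Homo sapiens) for inhibition, tested at 1 uM (on this read-out higher numbers stand for a stronger effect at the one concentration tested and lower numbers for a weaker effect), and gives 24.4%. Compound 1 `Cc1ccc(S(=O)(=O)n2cc(-c3cc(C(F)(F)F)ccn3)c3cc(OCc4ccccc4)ccc32)cc1` gives 23.2% in this assay, and the two numbers lie within the scatter of one another, so neither stands apart. Compound 3 `COc1ccc2c(c1)c(-c1cc(C(F)(F)F)cc(-c3cn(S(=O)(=O)c4ccc(C)cc4)c4ccc(OC)cc34)n1)cn2S(=O)(=O)c1ccc(C)cc1` differs from compound 2 by one change: hydrogen in place of cyano on an aromatic carbon. Within the data shown here, no measured pair shows a comparable change, so the step is expected to lie within the scatter, with no clear direction. Compound 3 is therefore expected to give about 22% in this assay, within 8% to 38%, an expected step of a number 2.4 percentage points lower from compound 2 to compound 3 (within the scatter).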

Compound 3, a percentage reported as inhibition, at one concentration (the size of the read-out at that concentration, not a potency): 7.1%
The estimate for compound 3 lay 14.9 percentage points above the measured number; measured number below the stated range.
By their numbers in this assay, from the lowest: compound 3; then compounds 1 and 2 (each within the scatter of the next).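

Hydrogen in place of cyano on the aromatic carbon ortho to a trifluoromethyl group gives, in this assay, a number 17.3 percentage points lower from compound 2 to compound 3 (beyond the scatter), so what this position carries matters for the effect at the one concentration tested. Among these compounds, the earlier compounds offered no comparison in one place, and this step is the first to show such a change. No measurement here explains the drop. As far as these compounds go, whether cyano is specifically required remains open, as a methyl group, a chlorine atom or a primary amide on this carbon would test, and so does whether the step would hold on another core.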